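A few compounds are considered here, and "the series" means these few. Any claim that something is new, unique, unknown or untested is made for them only; others in the source may bear on it.

In an assay on isolated protein for inhibition of aldehyde dehydrogenase 1A1 (Homo sapiens), read by spectrophotometry, tested at 10 uM (a higher number here means more inhibition at the concentration tested (going by the name of the read-out), a lower number less inhibition), compound 1 `Cc1cccc(Cn2c(CN3CCN(C(=O)C4CCCC4)CC3)nc3ccccc32)c1` gives 67.5%, compound 2 `Cc1cccc(Cn2c(CN3CCN(C(=O)c4ccc(C#N)cc4)CC3)nc3ccccc32)c1` gives 20.8%, and compound 3 `Cc1cccc(Cn2c(CN3CCN(C(=O)c4ccncc4)CC3)nc3ccccc32)c1` gives 20.6%. Compound 3 thus stands lowest of the three numbers, though its value and that of compound 2 lie within the scatter of each other, whereas compound 1 sits far higher.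

Compound 4 `Cc1cccc(Cn2c(CN3CCN(C(=O)c4ccc(Cl)cc4)CC3)nc3ccccc32)c1` differs from compound 3 in one place: 4-chlorophenyl in place of pyridin-4-yl on a carbonyl carbon. The step that bears most directly on this change is a number 0.2 percentage points lower from compound 2 to compound 3 (within the scatter), an exchange of one six-membered aromatic ring for another on the same carbonyl carbon that left the read-out unchanged. The large steps of a number 46.7 percentage points lower from compound 1 to compound 2 (beyond the scatter) and a number 46.9 percentage points lower from compound 1 to compound 3 (beyond the scatter) concern the loss of cyclopentyl and do not apply here.

Compound 4 is therefore expected to show a number 4.4 percentage points higher from compound 3 to compound 4 (within the scatter), with an estimate of 25% in a range of 8% to 48%.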

Compound 4, a percentage reported as inhibition, at one concentration (the size of the read-out at that concentration, not a potency): 23.2%
Compound 4: the middle estimate sits 1.8 percentage points above what was measured; the measured number falls inside the stated range.
By their numbers in this assay, from the lowest: compounds 3, 2 and 4 (each within the scatter of the next); then compound 1.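

In this assay, 4-chlorophenyl, a ring of carbon only, reads the same as the pyridin-4-yl ring with its hetero atom (a number 2.6 percentage points higher from compound 3 to compound 4 (within the scatter)), and exchanging cyano for chloro also makes no difference beyond the scatter (a number 2.4 percentage points higher from compound 2 to compound 4 (within the scatter)). All three aromatic rings on this carbonyl carbon now lie well under cyclopentyl, the chloro ring included (a number 44.3 percentage points lower from compound 1 to compound 4 (beyond the scatter)). No available evidence explains this gap. On these data alone, whether cyclohexyl or an open chain such as tert-butyl would hold the higher number remains open, as does the reading of unsubstituted phenyl.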